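A few compounds are considered here, and "the series" means these few. Any claim that something is new, unique, unknown or untested is made for them only; others in the source may bear on it.

In a functional assay on SK-MEL-5 cells (Homo sapiens) for inhibition, read by sulforhodamine B assay, with a stated time of 48 h (a lower number here means a stronger inhibitor of growth, a higher number a weaker inhibitor of growth), the three measured compounds give the following:

compound 1 `Nc1cc(N)c2nc(-c3ccccc3)c(NCc3ccc(Cl)c(Cl)c3)nc2c1`, which gives 3470 nM
compound 2 `CCOC(=O)[C@H](CCC(=O)O)NC(=O)c1ccc(Sc2nc3cc(N)cc(N)c3nc2-c2ccccc2)cc1`, which gives 12600 nM
compound 3 `CCOC(=O)[C@H](CCC(=O)O)NC(=O)c1ccc(Oc2nc3cc(N)cc(N)c3nc2-c2ccccc2)cc1`, which gives 18200 nM

Compound 1 stands lowest of the three in this assay. Its nearest neighbour is compound 2, whose number is higher by an amount beyond the usual scatter, and compound 3 lies further still, also beyond the scatter. Compounds 2 and 3 carry a different kind of substituent on the shared core, so their values say only where compound 1 stands among them, not what any single change is worth.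

Compound 4 `Nc1cc(N)c2nc(-c3ccccc3)c(NCc3ccc(F)cc3)nc2c1` is not yet measured. It differs from compound 1 in one place: 4-fluorophenyl in place of 3,4-dichlorophenyl on a saturated chain carbon bound to a nitrogen on an aromatic ring. The change takes away one ring substituent of the two chlorines and puts one fluorine in its place, leaving the rest of the compound untouched.

Among the measured compounds shown here, no measured pair shows this kind of swap, so the step from compound 1 to compound 4 is an expectation only. The step of a 1.7-fold higher number from compound 1 to compound 4 (0.24 log units; within the scatter) is expected to be a modest weakening, somewhat beyond the scatter. Compound 4 is therefore estimated to give 6000 nM in this assay, within a range from 2500 nM to 15000 nM.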

Compound 4, concentration for 50% growth inhibition: 1860 nM
Beside the measured number, compound 4's estimate is 3.2-fold (0.51 log units) above it; measured number outside the range, below it.
By their numbers in this assay, from the lowest: compounds 4 and 1 (each within the scatter of the next); then compounds 2 and 3 (each within the scatter of the next).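

Among the compounds shown here, the step of a 1.9-fold lower number from compound 1 to compound 4 (0.27 log units; within the scatter) in this assay is the first reading of a single change at this position. For the compounds shown here, compounds 2 and 3 differ from compound 1 by a different kind of substituent and give no such step. Exchanging 3,4-dichlorobenzyl for 4-fluorobenzyl leaves two compounds that this assay cannot tell apart, so for this one pair the two chlorines are not required for growth inhibition of this size, provided a fluorine stands on the ring instead. No supporting measurement accompanies these numbers to say why the swap makes so little difference.

Because the swap removes both chlorines and adds a fluorine in one step, the part played by each of these atoms stays unresolved, and a plain benzyl group or a 4-chlorobenzyl group would be needed to separate them. From the compounds shown here alone, it is also open how far this tolerance extends, for example to a carboxylic acid or an amine on the same ring, or to a longer chain between the ring and the nitrogen.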